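A methoxy group on the frame of compound 1

The source may report more compounds than this note shows. Statements on the series, on what has been measured and on what is new or still open speak of the compounds shown alone.

Values in an ADME assay on L6 cells (Rattus norvegicus) for cytotoxicity (a higher number here means a weaker inhibitor, a lower number a stronger inhibitor), are as follows
Compound 1 `c1cc(C2=NCCN2)cc(-c2cc3cc(C4=NCCN4)ccc3o2)c1` gives 33900 nM
Compound 2 `CC(C)NC(=N)c1ccc(-c2cc3cc(C(=N)NC(C)C)cc(O)c3o2)c(O)c1` gives > 179000 nM (a limit of the assay)

Of these two compounds, only compound 1 has an actual number in this assay and so stands as the sole reference point. Compound 2 reports only a limit (> 179000 nM) and offers no number for comparison. Compound 3 (`COc1ccc(C2=NCCN2)cc1-c1cc2cc(C3=NCCN3)ccc2o1`) keeps the core of compound 1 and carries methoxy in place of hydrogen on an aromatic carbon. For the measured compounds named here, no measured pair shows what such a change does in this assay and no step beyond the scatter is expected, in either direction. The expectation therefore rests on compound 1 (33900 nM) alone. The expected change (a 1.0-fold lower number from compound 1 to compound 3 (0.01 log units; within the scatter)) is an estimate and remains small. For compound 3 the estimated value is 33000 nM, with an expected range from 11000 nM to 100000 nM.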

Compound 3, half-maximal inhibitory concentration: 30800 nM
For compound 3 the middle estimate is 1.1-fold (0.03 log units) above the measured one; the range from low to high includes it.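

In this assay, methoxy in place of hydrogen on an aromatic carbon, ortho to a large group and para to a group of 5 heavy atoms, gives a 1.1-fold lower number from compound 1 to compound 3 (0.04 log units; within the scatter) and is the first step shown for any change to the frame of compound 1. At this position, the methoxy group therefore leaves compound 3 and compound 1 indistinguishable in this read-out, although a group of 2 heavy atoms has replaced a hydrogen atom. Nothing shown bears on the reason for this result.

Only methoxy is shown at this position, so it remains open whether an amine, a carboxylic acid or a longer chain on the same aromatic carbon would also stay within the scatter. As far as these compounds go, it also remains open whether methoxy on another aromatic carbon of the shared core would do so.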